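Removing a Methoxy Group from Compound 2

This account rests on a few compounds, and the source may have more. Where it says the series, first, only, none or still open, it means among the compounds named here.

Measured so far:
compound 1 `COc1ccc(C2=NNC(c3c(Cl)cccc3Cl)C2)cc1`: 60%
compound 2 `COc1ccc(C2=NN(C(=O)CBr)C(c3c(Cl)cccc3Cl)C2)cc1OC`: 69%

In a functional assay on the whole organism (strain albino) for inhibition, with Rattus norvegicus as the target, read by paw edema, with stated times of 30 min and 3 h, at a dose of 100 mg/kg by the oral route (a lower number here means less inhibition, a higher number more inhibition at the dose given (going by the name of the read-out)), compound 2 gives 69%, the highest of the two numbers shown. Its nearest neighbour, compound 1, gives 60%, which lies within the scatter of compound 2, so the two cannot be ranked against each other. Going by the values given here, compound 1 differs from compound 2 in two places, so no single-change step between measured compounds is known.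

Compound 3 `COc1ccc(C2=NN(C(=O)CBr)C(c3c(Cl)cccc3Cl)C2)cc1` has not yet been measured in this assay. It differs from compound 2 by hydrogen in place of methoxy on an aromatic carbon. Among the compounds with values here, with no measured step to lean on, the expectation for this change is a step of no more than the scatter, in no clear direction. For compound 3 the estimated value in this assay is 62%, with a range from 45% to 78%. That estimate means an expected step of a number 7 percentage points lower from compound 2 to compound 3 (within the scatter), within the scatter.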

Compound 3, a percentage reported as inhibition, in the whole organism at one dose (the size of the read-out at that dose, not a potency): 7%
The estimate for compound 3 lay 55 percentage points above the measured number; the measured number lies below the stated range.
By their numbers in this assay, from the lowest: compound 3; then compounds 1 and 2 (each within the scatter of the next).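

In this assay, hydrogen in place of methoxy at this place, ortho to a methoxy group and meta to a large group, gives a number 62 percentage points lower from compound 2 to compound 3 (beyond the scatter), so this single methoxy group matters greatly in this series. Adding (bromomethyl)carbonyl in place of hydrogen on the ring amine nitrogen gives a number 53 percentage points lower from compound 1 to compound 3 (beyond the scatter), so when only one methoxy group is present, this change also goes with a large loss. No measurement shown here explains either drop.

Going by these compounds, it remains open whether the second methoxy group would matter as much with hydrogen on that nitrogen. Nor do these compounds show whether a hydroxyl group, a fluorine atom or a longer ethoxy chain at this place would keep the inhibition seen for compound 2.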